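The compounds below may be only part of what the source reports. "The series", "measured", "known", "first", "only" and "open" are said of these compounds alone.

Of the compounds shown here, three built on one shared core have been tested in an assay on HL-60 cells for inhibition of glutathione S-transferase P (Homo sapiens), read by spectrophotometry, tested at 20 uM; on this read-out higher numbers stand for more inhibition at the one concentration tested (going by the name of the read-out) and lower numbers for less inhibition. Compound 1 `Cc1cccc2c1N(CC(=O)O)C/C(=C\c1ccc(F)cc1)C2=O` gives 22.9% in this assay. Compound 2 `Cc1ccc(/C=C2\CN(CC(=O)O)c3c(C)cccc3C2=O)cc1` gives 46.8%. Compound 3 `Cc1cccc(/C=C2\CN(CC(=O)O)c3c(Cl)cccc3C2=O)c1` gives 45.6%, the second highest of the three numbers; its gap to compound 2 lies within the scatter, while compound 1 sits clearly lower. Among the measured compounds shown here, the only step between two compounds that differ in one place is a number 23.9 percentage points higher from compound 1 to compound 2 (beyond the scatter), a methyl in place of fluoro on an aromatic carbon. Compound 4 `Cc1cccc(/C=C2\CN(CC(=O)O)c3c(C)cccc3C2=O)c1` differs from compound 3 by methyl in place of chloro on an aromatic carbon, on an aromatic carbon of the fused system. For the measured compounds named here, no measured step covers a chloro-to-methyl exchange, so the fluoro-to-methyl step bears on it only loosely. Compound 2, which also carries a methyl rather than chloro on that aromatic carbon, gives a number within the scatter of compound 3. Compound 4 is therefore expected to show a number 0.4 percentage points higher from compound 3 to compound 4 (within the scatter), no step beyond the scatter. The estimate for compound 4 is 46%, ranging from 32% to 60%.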

Compound 4, a percentage reported as inhibition, at one concentration (the size of the read-out at that concentration, not a potency): 39.1%
Estimate against measurement, compound 4: 6.9 percentage points above; measured number inside the range.
By their numbers in this assay, from the lowest: compound 1; then compounds 4, 3 and 2 (each within the scatter of the next).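

In this assay methyl in place of chloro on this aromatic carbon of the fused system gives a number 6.5 percentage points lower from compound 3 to compound 4 (within the scatter) and so, at the one concentration tested, the position takes either group with no step beyond the scatter. On the double-bonded chain carbon, 3-methylphenyl in place of 4-methylphenyl gives a number 7.7 percentage points lower from compound 2 to compound 4 (within the scatter) and stays within the scatter too, while 3-methylphenyl in place of 4-fluorophenyl gives a number 16.2 percentage points higher from compound 1 to compound 4 (beyond the scatter) and so lies beyond it, which sets compound 1 apart from compound 4 as well as from compound 2. Nothing available accounts for these numbers.

Going by these compounds, whether an amine or a nitrile on the same aromatic carbon would stay within the scatter of chloro and methyl remains open. So does whether a 4-fluorophenyl group would give a comparable step with chloro on that carbon.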